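Diamino triazolo core: predicting the step from hydroxy to amino

The source may hold more compounds than are shown below. What is called first, only, known or untested is meant among the compounds shown, and "the series" means these compounds.

Measured so far, in a functional assay on L1210 cells (Mus musculus) for antiproliferative activity; a higher number here means a weaker inhibitor, a lower number a stronger inhibitor: compound 1 `Nc1nc(Cl)c2nnn([C@H]3CCC[C@H]3CO)c2n1` gives 71000 nM; compound 2 `Nc1nc(O)c2nnn([C@H]3CCC[C@H]3CO)c2n1` gives 80000 nM; compound 3 `Nc1nc(N)c2ncn([C@H]3CCC[C@H]3CO)c2n1` gives 113000 nM.

All three numbers lie close together. Compound 2 differs from compound 1 by a 1.1-fold higher number from compound 1 to compound 2 (0.05 log units; within the scatter), so the exchange of chloro for hydroxy on the shared core left the number where it was. Compound 3, which carries two amino groups on a core that differs from that of compound 2 in one ring atom, gives a number that is also within the scatter of compound 2. Compound 2 therefore stands neither apart from nor clearly away from its neighbours.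

Compound 4 `Nc1nc(N)c2nnn([C@H]3CCC[C@H]3CO)c2n1` has not yet been measured. It is reached from compound 2 by amino in place of hydroxy on an aromatic carbon. Going by the values given here, the only measured step at that position, from chloro to hydroxy, was within the scatter, and the diamino compound 3 sits at a similar level, which suggests that a swap of one small group for another at this place does not move the number much. For compound 4 the expected step is a 1.2-fold higher number from compound 2 to compound 4 (0.07 log units; within the scatter), within the scatter. The estimate for compound 4 is 95000 nM, with a range from 40000 nM to 230000 nM.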

Compound 4, half-maximal inhibitory concentration: 77200 nM
Compound 4: the middle estimate sits 1.2-fold (0.09 log units) above what was measured; low and high end bracket the measured number.
By their numbers in this assay, from the lowest: compounds 1, 4, 2 and 3 (each within the scatter of the next).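

In this assay, amino in place of hydroxy gives a 1.0-fold lower number from compound 2 to compound 4 (0.02 log units; within the scatter), and amino in place of chloro gives a 1.1-fold higher number from compound 1 to compound 4 (0.04 log units; within the scatter). Going by these compounds alone, with these two steps, chloro, hydroxy and amino have all been compared directly at this one aromatic carbon on the shared core, whereas before only the swap of chloro for hydroxy had been seen there, and no pair of the three can be told apart in this assay. So the flat picture no longer rests on a single step, although nothing measured here can say why the three groups read alike.

Whether a bulkier group at this carbon, such as methoxy, dimethylamino or a phenyl ring, would move the number beyond the scatter stays open, since the compounds shown hold only chloro, hydroxy and amino there. It is equally open whether the same holds on the core of compound 3, where only the amino group is shown, so a chloro or hydroxy group on that core would be needed to test it.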